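A few compounds are considered here, and "the series" means these few. Any claim that something is new, unique, unknown or untested is made for them only; others in the source may bear on it.

Four compounds share one core and differ only in the group attached to it. Compound 1 has the structure `Cc1ccccc1-c1nnc(NNC(C)C)s1`. Compound 3, with the structure `Cc1ccccc1-c1nnc(N(C)NC(C)C)s1`, differs from it by methyl in place of hydrogen on a nitrogen on an aromatic ring. Compound 2 has the structure `Cc1ccccc1-c1nnc(NNC(c2ccccc2)c2ccccc2)s1`; the difference between its core and the core of compound 1 is not broken down here. Compound 4, with the structure `Cc1ccccc1-c1nnc(N(C)NC(c2ccccc2)c2ccccc2)s1`, has not yet been measured and differs from compound 2 by methyl in place of hydrogen on a nitrogen on an aromatic ring, which is the same change as that from compound 1 to compound 3, made at the same place.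

In a functional assay on the whole organism with Mus musculus as the target, in the maximal electroshock model, with a stated time of 1 h (on this read-out lower numbers stand for an effect already at smaller amounts and higher numbers for an effect only at larger amounts of compound), compound 1 gives 83 mg/kg. In the same read-out compound 3 gives 35 mg/kg. That change made a 2.4-fold lower number from compound 1 to compound 3 (0.38 log units; beyond the scatter). For compound 2, by contrast, the assay reports only a limit, > 200 mg/kg, and no number. This is the limit of > 200 mg/kg in this assay, at which 1 of the 3 values shown sits.

Because a 2.4-fold lower number from compound 1 to compound 3 (0.38 log units; beyond the scatter) was a modest gain, the same kind of gain is expected here too, so the step for compound 4 is estimated as an at least 1.1-fold lower number from compound 2 to compound 4 (0.04 log units; that floor lies within the scatter). Since the starting point for compound 2 is known only as a limit, this expectation is loose. Compound 4 is therefore expected to give roughly 180 mg/kg in this assay. A second limit, rather than a number, would not be surprising.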

Compound 4, dose for half-maximal effect: > 200 mg/kg
Compound 4: a limit, no number; the forecaster's own chance of this, stated with the estimate: 55%; middle value at least 1.1-fold (0.04 log units) away from the limit.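

For the compounds shown here, compound 2 and compound 4 are each reported by this assay only as a limit, not as a number, so no step between them can be read. Both sit at the same limit: the limit of > 200 mg/kg in this assay, at which 2 of the 4 values shown sit. The compounds shown leave open whether methyl in place of hydrogen on this nitrogen changes the dose needed when the group of compound 2 is present.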